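The source may report more compounds than this note shows. Statements on the series, on what has been measured and on what is new or still open speak of the compounds shown alone.

Measured compounds:
compound 1 `C=CCOC(=O)NC[C@H]1OC(N(CC2=CC[C@@H](C(=C)C)CC2)OC)[C@H](O)[C@@H](O)[C@@H]1O`, 140000 nM
compound 2 `C=C(C)[C@@H]1CC=C(CN(OC)C2O[C@H](CO)[C@@H](O)[C@H](O)[C@H]2N=[N+]=[N-])CC1`, 221000 nM
compound 3 `C=C(C)[C@@H]1CC=C(CN(OC)C2O[C@@H](CO)[C@H](N=[N+]=[N-])[C@@H](O)[C@@H]2O)CC1`, 451000 nM

In a functional assay on A549 cells (Homo sapiens) for cytotoxicity, read by resazurin assay, with a stated time of 48 h (on this read-out lower numbers stand for stronger inhibition and higher numbers for weaker inhibition), compound 1 gives the lowest of the three numbers. Compound 2 sits within the scatter of compound 1, so the two cannot be told apart, while compound 3 lies beyond the scatter. Compound 4 `C=C(C)[C@@H]1CC=C(CN(OC)C2OC[C@@H](O)[C@H](O)[C@H]2O)CC1` has not yet been measured. It differs from compound 1 in one place: hydrogen in place of ((allyloxycarbonyl)amino)methyl on a saturated ring carbon. For the measured compounds named here, with no measured step of this kind to lean on, and all three numbers sitting weakly active, the step from compound 1 to compound 4 is expected to stay small, most likely toward a higher number, as a 1.6-fold higher number from compound 1 to compound 4 (0.20 log units; within the scatter). Compound 4 is therefore expected near 220000 nM, with a range from 80000 nM to 600000 nM.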

Compound 4, half-maximal inhibitory concentration: 202000 nM
Beside the measured number, compound 4's estimate is 1.1-fold (0.04 log units) above it; the range from low to high includes it.
By their numbers in this assay, from the lowest: compounds 1, 4 and 2 (each within the scatter of the next); then compound 3.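

Within this assay this place, next to the ring oxygen, gets its first direct reading: hydrogen in place of ((allyloxycarbonyl)amino)methyl gives a 1.4-fold higher number from compound 1 to compound 4 (0.16 log units; within the scatter) and so the two compounds cannot be told apart. The whole side group can leave this saturated ring carbon without a readable change, and both compounds remain weakly active. Nothing measured here offers a reason for this result. Still open, going by these compounds, is whether a free aminomethyl or a carboxylic acid on this carbon would move the number beyond the scatter.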